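A few compounds are considered here, and "the series" means these few. Any claim that something is new, unique, unknown or untested is made for them only; others in the source may bear on it.

Measured in a physicochemical assay for lipophilicity, read by HPLC, at pH 7.5 (a higher number here means a more lipophilic compound, a lower number a more polar compound), so far:
compound 1 `CC[C@@H](Nc1c(C#N)c(-c2ccc(-c3cccc(C)c3F)cc2)nc2cnccc12)C(N)=O` gives 3
compound 2 `CCOc1ccccc1-c1ccc(-c2nc3cnccc3c(N[C@H](CC)C(=O)N(C)C)c2C#N)cc1` gives 3.7

Compound 1 holds the lower of these two numbers, and the gap up to compound 2 lies beyond the scatter. The two differ in more than one place, so no measured pair sizes a single change.

Compound 3 `CC[C@@H](Nc1c(C#N)c(-c2ccc(-c3ccc(F)cc3)cc2)nc2cnccc12)C(N)=O` has yet to be measured. It differs from compound 1 by 4-fluorophenyl in place of 2-fluoro-3-methylphenyl on an aromatic carbon and the change stands para to a large group. With 3 as the starting value of compound 1 and a smaller group entering, a small downward step in this assay is expected, no larger than the scatter. The estimate is a number 0.30 log units lower from compound 1 to compound 3 (within the scatter) for this change. For compound 3 the estimated value is 2.7 with an expected range from 2.4 to 3 in this measurement.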

Compound 3, distribution coefficient: 2.7
For compound 3 middle estimate and measured number coincide at the digits printed; the measured number falls inside the stated range.
By their numbers in this assay, from the lowest: compounds 3 and 1 (each within the scatter of the next); then compound 2.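

For the compounds shown here, this is the first single change sized: on an aromatic carbon, para to a large group, 4-fluorophenyl in place of 2-fluoro-3-methylphenyl gives a number 0.30 log units lower from compound 1 to compound 3 (within the scatter) in this assay. The swap takes the group from 8 heavy atoms to 7 with no hydrogen-bond donor or acceptor on either side, and on this reading the two compounds are not separated. Nothing available accounts for the size of this step.

Going by these compounds alone, the single step also combines the loss of the methyl with the new place of the fluorine, so neither can be read alone. Going by these compounds, how far the number would move with a group of another kind at this place, such as an amine, a carboxylic acid or a longer alkyl chain, stays open.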